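The source may hold more compounds than are shown below. What is called first, only, known or untested is meant among the compounds shown, and "the series" means these compounds.

Three compounds on a shared core differ only in the groups on an amine nitrogen. In a functional assay on MCF7 cells (Homo sapiens) for antiproliferative activity (on this read-out higher numbers stand for weaker inhibition and lower numbers for stronger inhibition), compound 1 (`CCN(C)CCCOc1ccc2cc(NC(=O)c3ccc(O)c(CC=C(C)C)c3)c(=O)oc2c1C`) gives 2190 nM and compound 2 (`CC(C)=CCc1cc(C(=O)Nc2cc3ccc(OCCCNC(C)C)c(C)c3oc2=O)ccc1O`) gives 740 nM, while compound 3 (`COC(=O)CNCCCOc1ccc2cc(NC(=O)c3ccc(O)c(CC=C(C)C)c3)c(=O)oc2c1C`) gives 2820 nM in the same test. Compound 3 cannot be told apart from compound 1 (a 1.3-fold higher number from compound 1 to compound 3 (0.11 log units; within the scatter)) but stands clearly above compound 2 (a 3.8-fold higher number from compound 2 to compound 3 (0.58 log units; beyond the scatter)).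

Compound 4 (`CC(C)=CCc1cc(C(=O)Nc2cc3ccc(OCCCNCC(=O)O)c(C)c3oc2=O)ccc1O`) brings one change (hydrogen in place of methyl on an oxygen next to a carbonyl group): hydrogen in place of methyl on an oxygen next to a carbonyl group, so methoxycarbonyl becomes carboxy. Within the data shown here, no measured step touches this group, so the evidence is indirect. The swaps on the nitrogen stayed modest, including the remaining one (a 3.0-fold lower number from compound 1 to compound 2 (0.47 log units; beyond the scatter)), so no step beyond the scatter is expected, though a modest rise remains possible. The expected change is small (a 1.2-fold higher number from compound 3 to compound 4 (0.09 log units; within the scatter)). For compound 4 the estimate is 3500 nM with an expected range from 1200 nM to 10000 nM.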

Compound 4, half-maximal inhibitory concentration: 18100 nM
The estimate for compound 4 lay 5.2-fold (0.71 log units) below the measured number; the whole stated range lies below it.
By their numbers in this assay, from the lowest: compound 2; then compounds 1 and 3 (each within the scatter of the next); then compound 4.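

In this assay, removing the single methyl from the methoxycarbonyl group gives a 6.4-fold higher number from compound 3 to compound 4 (0.81 log units; beyond the scatter) and turns it into carboxy, even though compound 3 could not be told apart from compound 1. Among these compounds, the carboxy compound also stands well clear of the other two amines, with an 8.3-fold higher number from compound 1 to compound 4 (0.92 log units; beyond the scatter) and with a 24-fold higher number from compound 2 to compound 4 (1.39 log units; beyond the scatter) as the only large step in the set. Nothing measured here explains this loss of activity. Still open, as far as these compounds go, is whether a carboxamide or an ethyl ester at this place, or a longer chain carrying the carboxy group, would behave like compound 3 or like compound 4.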